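Methoxy gives way to propyl on the shared core

The compounds below may be only part of what the source reports. "The series", "measured", "known", "first", "only" and "open" are said of these compounds alone.

Measured so far in a functional assay on brain (Rattus norvegicus, strain Wistar) for inhibition; on this read-out lower numbers stand for stronger inhibition and higher numbers for weaker inhibition
compound 1 `CCCCOc1ccc(-c2c(C)[nH]c(=O)n2C)cc1` gives 5100 nM
compound 2 `COc1ccc(-c2c(C)[nH]c(=O)n2C)cc1` gives 147000 nM

Compound 2 has the higher of the two numbers and is the weaker inhibitor. Compound 3 `CCCc1ccc(-c2c(C)[nH]c(=O)n2C)cc1`, not yet measured, carries propyl in place of methoxy on an aromatic carbon of the same core. Going by the values given here, one measured step bears on this change. That step, a 29-fold higher number from compound 1 to compound 2 (1.46 log units; beyond the scatter), is large and takes a propyl away from a saturated chain carbon bound to an oxygen. Compound 3 also has a propyl, but without that oxygen, so only part of that step is expected to apply. The expectation is a 7.4-fold lower number from compound 2 to compound 3 (0.87 log units; beyond the scatter) in this assay, which is smaller than the measured step. For compound 3 the estimated value is 20000 nM (range 6000 nM to 70000 nM).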

Compound 3, half-maximal inhibitory concentration: 21500 nM
Beside the measured number, compound 3's estimate is 1.1-fold (0.03 log units) below it; measured number inside the range.
By their numbers in this assay, from the lowest: compound 1; then compound 3; then compound 2.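

In this assay, an oxygen on this aromatic carbon is not needed for a lower number than methoxy gives: propyl in place of methoxy yields a 6.8-fold lower number from compound 2 to compound 3 (0.83 log units; beyond the scatter). Propyl still falls short of butoxy, with a 4.2-fold higher number from compound 1 to compound 3 (0.62 log units; beyond the scatter), so the number falls from methoxy through propyl to butoxy, and none of these compounds goes against that order. Nothing available explains these differences.

Going by these compounds, what propoxy would give beside propyl, and so what the oxygen contributes at equal chain length, stays open. On these data alone, whether a longer chain such as hexyloxy would extend the order, or an amine would break it, is also open.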